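Removing One Methoxy Group: Expected Growth Inhibition of Compound 4

The source may hold more compounds than are shown below. What is called first, only, known or untested is meant among the compounds shown, and "the series" means these compounds.

Three measured compounds frame the question. Compound 1 `COc1ccc(-c2cc(/C=C/C(=O)c3ccc(N)cc3)[nH]n2)cc1` gives 10200 nM in a functional assay on A549 cells (Homo sapiens) for inhibition, read by sulforhodamine B assay, with a stated time of 48 h; on this read-out lower numbers stand for stronger inhibition of growth and higher numbers for weaker inhibition of growth. Compound 2 `COc1ccc(-c2cc(/C=C/C(=O)c3ccc(N)cc3)[nH]n2)cc1OC` gives 10100 nM in this assay. Compound 3 `COc1cc(C(=O)/C=C/c2cc(-c3cc(OC)c(OC)c(OC)c3)n[nH]2)cc(OC)c1OC` gives 12100 nM in this assay; the difference between the cores of compound 2 and compound 3 is not broken down here. The change from compound 2 to compound 1 is hydrogen in place of methoxy on an aromatic carbon, and the step it made is a 1.0-fold higher number from compound 2 to compound 1 (0.00 log units; within the scatter). Compound 4 `COc1ccc(-c2cc(/C=C/C(=O)c3cc(OC)c(OC)c(OC)c3)[nH]n2)cc1OC` has not yet been measured; it differs from compound 3 by hydrogen in place of methoxy on an aromatic carbon, the same kind of change, though here the place is also meta to a methoxy group. For the measured compounds named here, the earlier step, a 1.0-fold higher number from compound 2 to compound 1 (0.00 log units; within the scatter), is the only guide available. On that basis the expected step is a 1.0-fold lower number from compound 3 to compound 4 (0.00 log units; within the scatter). The estimate for compound 4 is 12000 nM, with a range from 6000 nM to 24000 nM.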

Compound 4, concentration for total growth inhibition: 9340 nM
The estimate for compound 4 lay 1.3-fold (0.11 log units) above the measured number; measured number inside the range.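

In this assay hydrogen in place of methoxy gave a 1.3-fold lower number from compound 3 to compound 4 (0.11 log units; within the scatter) on the core of compound 3, a step no larger than the scatter, as on the core of compound 2. The two steps do not differ: the same change on two cores in this assay, a 1.0-fold higher number (0.00 log units; within the scatter) from compound 2 to compound 1 and a 1.3-fold lower number (0.11 log units; within the scatter) from compound 3 to compound 4, 1.3-fold (0.12 log units) apart, within the scatter of two such steps. This shows that the change carried from one core to the other without a step beyond the scatter, but it rests on two pairs only and does not show that it would stay this small on any other core or at any other place.

The compounds shown leave open whether ethoxy, a chlorine atom or a carboxylic acid in that same place would move the number beyond the scatter.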